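The source may report more compounds than this note shows. Statements on the series, on what has been measured and on what is new or still open speak of the compounds shown alone.

Working notes on the series, read in a functional assay on NCI-H727 cells (Homo sapiens) for antiproliferative activity, with a stated time of 48 h; a higher number here means a weaker inhibitor, a lower number a stronger inhibitor. Compound 1 (`CCN(CC)c1ccc(-c2cccc(OC)c2)nn1`) gives > 25000 nM, which is a limit and not a number. Compound 2 (`CC(=O)c1ccc(-c2ccc(N3CCCC3)nn2)cc1`), which carries an acetyl group, gives > 25000 nM, also a limit. Compound 3 (`CCN(CC)c1ccc(-c2ccc(C#N)cc2)nn1`) gives > 25000 nM, again a limit, so it has no number of its own. All three compounds share one position: the limit of > 25000 nM in this assay, at which 3 of the 3 values shown sit. Compound 4 (`CCN(CC)c1ccc(-c2ccc(C(C)=O)cc2)nn1`) has acetyl in place of cyano on an aromatic carbon, para to a large group: acetyl in place of cyano on an aromatic carbon. Among the compounds with values here, no measured step exists. In this assay, within the data shown here, the change is expected to give no step beyond the scatter, with compound 2 at > 25000 nM as the only guide. The expected step is a step that the limit leaves unreadable from compound 3 to compound 4. For compound 4 the estimated value is 28000 nM, with an expected range from 12000 nM to 60000 nM.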

Compound 4, half-maximal inhibitory concentration: 25000 nM
Compound 4: the middle estimate sits 1.1-fold (0.05 log units) above what was measured; measured number inside the range.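

In this assay compound 4 gives 25000 nM as the only actual number among the compounds shown rather than a limit. The size of both steps reaching compound 4 cannot be read. Diethylamino in place of pyrrolidin-1-yl gives a number no higher from compound 2 to compound 4 (the limit leaves the size open) as one of these steps. The other compounds all remain at a limit: the limit of > 25000 nM in this assay, at which 3 of the 4 values shown sit.

Acetyl in place of cyano gives a number no higher from compound 3 to compound 4 (the limit leaves the size open) and whether any group at this aromatic carbon gives a number clearly lower remains open. A carboxylic acid or an amine in place of acetyl would test this position.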